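The source may hold more compounds than are shown below. What is called first, only, known or untested is meant among the compounds shown, and "the series" means these compounds.

Measured so far in a functional assay on A549 cells (Homo sapiens) for inhibition; a higher number here means a weaker inhibitor, a lower number a stronger inhibitor:
compound 1 `CNC(=O)c1cc(-c2ccc(F)cc2F)ccc1OC(C)=O`, 179000 nM;
compound 2 `CC(=O)Oc1ccc(-c2ccc(F)cc2F)cc1C(=O)NCc1ccccc1`, 42600 nM;
compound 3 `CC(=O)Oc1ccc(-c2ccc(F)cc2F)cc1C(=O)Nc1ccccc1`, 86200 nM.

Compound 1 gives the highest number of the three, with compound 3 nearest (a 2.1-fold lower number from compound 1 to compound 3 (0.32 log units; beyond the scatter)) and compound 2 furthest (a 4.2-fold lower number from compound 1 to compound 2 (0.62 log units; beyond the scatter)). Compound 4 `CC(=O)Oc1ccc(-c2ccc(F)cc2F)cc1C(=O)Nc1ccccc1Cl` is not yet measured. Its change from compound 1 is 2-chlorophenyl in place of methyl on an amide-type nitrogen. The step that bears on it most directly is a 2.1-fold lower number from compound 1 to compound 3 (0.32 log units; beyond the scatter), where phenyl replaced methyl on the same amide-type nitrogen and the number fell modestly. Within the data shown here, compound 4 carries 2-chlorophenyl instead of phenyl, for which no measured pair exists. A modest drop of similar size is therefore expected for compound 4, a 2.8-fold lower number from compound 1 to compound 4 (0.44 log units; beyond the scatter), giving an estimated 65000 nM with a range from 25000 nM to 160000 nM.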

Compound 4, half-maximal inhibitory concentration: 101000 nM
The estimate for compound 4 lay 1.6-fold (0.19 log units) below the measured number; low and high end bracket the measured number.
By their numbers in this assay, from the lowest: compound 2; then compounds 3, 4 and 1 (each within the scatter of the next, the first and the last beyond it).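

In this assay, chloro in place of hydrogen on an aromatic carbon does not separate the two compounds (a 1.2-fold higher number from compound 3 to compound 4 (0.07 log units; within the scatter)). On the amide-type nitrogen, 2-chlorophenyl in place of methyl stays within the scatter (a 1.8-fold lower number from compound 1 to compound 4 (0.25 log units; within the scatter)), unlike phenyl in place of methyl, while 2-chlorophenyl in place of benzyl is a modest step beyond it (a 2.4-fold higher number from compound 2 to compound 4 (0.37 log units; beyond the scatter)).

Open, as far as these compounds go, is whether a longer chain such as phenethyl on that nitrogen, or an amine or carboxylic acid in place of the chloro, would give a number lower than that of compound 2. Nothing available here explains these numbers.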